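A few compounds are considered here, and "the series" means these few. Any claim that something is new, unique, unknown or untested is made for them only; others in the source may bear on it.

In a functional assay on DU-145 cells (Homo sapiens) for cytotoxicity, read by sulforhodamine B assay, with a stated time of 48 h (on this read-out lower numbers stand for stronger inhibition and higher numbers for weaker inhibition), compound 1 (`COc1ccc(C2=NO[C@]3(C2)C(=O)O[C@@H]2[C@H]3CC[C@H](C)[C@]3(O)C=CC(=O)[C@@]23C)cc1`) gives 20000 nM, compound 2 (`C[C@H]1CC[C@@H]2[C@@H](OC(=O)[C@]23CC(c2ccccc2Br)=NO3)[C@]2(C)C(=O)C=C[C@@]12O`) gives 18000 nM and compound 3 (`C[C@H]1CC[C@@H]2[C@@H](OC(=O)[C@]23CC(c2ccccc2F)=NO3)[C@]2(C)C(=O)C=C[C@@]12O`) gives 24000 nM, which places compound 3 level with the other two, within the scatter. Compound 4 (`C[C@H]1CC[C@@H]2[C@@H](OC(=O)[C@]23CC(c2ccc(C#N)cc2)=NO3)[C@]2(C)C(=O)C=C[C@@]12O`) carries 4-cyanophenyl in place of 2-fluorophenyl on a carbon with a double bond to nitrogen. Two measured changes of the group at that carbon bear on this: a 1.2-fold higher number from compound 1 to compound 3 (0.08 log units; within the scatter) and a 1.3-fold higher number from compound 2 to compound 3 (0.12 log units; within the scatter). For the measured compounds named here, no compound with a nitrile has been measured, so this remains an extrapolation. In this assay, the step expected is a 1.2-fold lower number from compound 3 to compound 4 (0.08 log units; within the scatter), with no direction expected beyond the scatter. Compound 4 is estimated at 20000 nM, with an expected range from 9000 nM to 40000 nM.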

Compound 4, half-maximal inhibitory concentration: 26000 nM
Beside the measured number, compound 4's estimate is 1.3-fold (0.11 log units) below it, and the stated range covers the measured number.
By their numbers in this assay, from the lowest: compounds 2, 1, 3 and 4 (each within the scatter of the next).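

The nitrile, new at this carbon, leaves the number in this assay level with all three earlier compounds (a 1.1-fold higher number from compound 3 to compound 4 (0.03 log units; within the scatter); a 1.4-fold higher number from compound 2 to compound 4 (0.16 log units; within the scatter); a 1.3-fold higher number from compound 1 to compound 4 (0.11 log units; within the scatter)). Among 2-bromophenyl, 2-fluorophenyl, 4-methoxyphenyl and 4-cyanophenyl, no step at this position now lies beyond the scatter, and this includes a change to a group with a triple bond. Nothing measured here accounts for this flat picture. Going by these compounds, whether an amine or a carboxylic acid on the phenyl ring, or a longer chain in place of that ring, would shift the number remains open.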